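The compounds below may be only part of what the source reports. "The series", "measured", "known", "first", "only" and "open" are said of these compounds alone.

Measured so far:
- compound 1 `CCOc1ccccc1N1CCN(CCCNc2ncccc2C(=O)N(C)C)CC1` gives 7.94 nM
- compound 2 `CN(C)C(=O)c1cccnc1NCCCN1CCN(c2ccccc2OC(F)(F)F)CC1` gives 100 nM
- compound 3 `CN(C)C(=O)c1cccnc1NCCCN1CCN(c2ccccc2OCC(C)(C)C)CC1` gives 50.1 nM

All three were tested in a functional assay on aorta for antagonist activity at Alpha-1D adrenergic receptor (Rattus norvegicus); a lower number here means tighter binding, a higher number weaker binding. Compound 1 has the lowest number of the three: compound 3 stands nearest, and compound 2 stands furthest. The two measured steps that start from compound 1 both alter what hangs on the oxygen on the aromatic ring. From compound 1 to compound 2 the number went up a 13-fold higher number from compound 1 to compound 2 (1.10 log units; beyond the scatter), and from compound 1 to compound 3 it went up a 6.3-fold higher number from compound 1 to compound 3 (0.80 log units; beyond the scatter). The pair compound 2 and compound 3 differ by a 2.0-fold lower number from compound 2 to compound 3 (0.30 log units; within the scatter).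

Compound 4 `COc1cc(O)ccc1N1CCN(CCCNc2ncccc2C(=O)N(C)C)CC1` has not yet been tested in this assay. It differs from compound 1 as follows: 4-hydroxy-2-methoxyphenyl in place of 2-ethoxyphenyl on an amine nitrogen in a ring. This is a different kind of change: the alkyl on the oxygen becomes smaller rather than larger, and a hydroxy is added to the ring. The measured steps bear on it only loosely, since both replaced the ethyl with something other than methyl and neither added a hydroxy. What they show is that every alteration at this oxygen so far has raised the number. A modest rise is therefore expected, a 2.5-fold higher number from compound 1 to compound 4 (0.40 log units; beyond the scatter), with wide uncertainty. Compound 4 is estimated at 20 nM, within a range of 4 nM to 100 nM.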

Compound 4, dissociation constant: 79.4 nM
Compound 4: the middle estimate sits 4.0-fold (0.60 log units) below what was measured; the range from low to high includes it.
By their numbers in this assay, from the lowest: compound 1; then compounds 3, 4 and 2 (each within the scatter of the next).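

In this assay the swap to 4-hydroxy-2-methoxyphenyl gives a 10-fold higher number from compound 1 to compound 4 (1.00 log units; beyond the scatter) and shows that the number is sensitive to more than what hangs on the oxygen, since this change also adds a hydroxy to the aromatic ring. The entering and leaving groups both count the same number of heavy atoms, so a rise of this size does not need a group with more heavy atoms, and none of the three changes made to compound 1 goes against the rise seen so far. No measurement shown gives a reason for this rise.

Two things change together in this step, a shorter chain on the oxygen and a new hydroxy, so the step cannot be divided between them, and a plain 2-methoxyphenyl and a 4-hydroxy-2-ethoxyphenyl would each carry only one of the two. Also open, on these data alone, is whether any group on this ring nitrogen, such as 2-isopropoxyphenyl, could give a lower number than compound 1 at 7.94 nM.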